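A nitro for a bromo on the shared core

The source may hold more compounds than are shown below. What is called first, only, known or untested is meant among the compounds shown, and "the series" means these compounds.

compound 1: `O=C(CSc1nnc(-c2ccncc2)o1)N/N=C/c1ccc(F)cc1` — 15700 nM
compound 2: `O=C(CSc1nnc(-c2ccncc2)o1)N/N=C/c1ccc(Br)cc1` — 21300 nM

Both compounds were tested in a functional assay on SW 1116 cells (Homo sapiens) for cytotoxicity, read by MTT assay, with a stated time of 48 h; a lower number here means a stronger inhibitor, a higher number a weaker inhibitor. Within the data shown here, compound 2 holds the highest of the two numbers so far, but its only neighbour is compound 1, and the step of a 1.4-fold higher number from compound 1 to compound 2 (0.13 log units; within the scatter) keeps the two within the scatter, so no order between them can be read.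

Compound 3 (`O=C(CSc1nnc(-c2ccncc2)o1)N/N=C/c1ccc([N+](=O)[O-])cc1`) differs from compound 2 in one place: nitro in place of bromo on an aromatic carbon. Among the measured compounds shown here, the only measured step on this part of the core is the halogen exchange a 1.4-fold higher number from compound 1 to compound 2 (0.13 log units; within the scatter), which changed nothing beyond the scatter. For the measured compounds named here, no measured pair shows a nitro group here, so the step from bromo to nitro has no direct precedent in these data, and the one related step gives no ground to expect a shift in this assay in either direction.

Compound 3 is therefore expected to sit close to compound 2, with the estimated step of a 1.2-fold lower number from compound 2 to compound 3 (0.07 log units; within the scatter) inside the usual spread. The estimate for compound 3 in this assay is 18000 nM, with a range from 7000 nM to 45000 nM.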

Compound 3, half-maximal inhibitory concentration: 25800 nM
The estimate for compound 3 lay 1.4-fold (0.16 log units) below the measured number; the measured number falls inside the stated range.
By their numbers in this assay, from the lowest: compounds 1, 2 and 3 (each within the scatter of the next).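

In this assay, a nitro group on this aromatic carbon, para to a large group, cannot be separated from either halogen: the step of a 1.2-fold higher number from compound 2 to compound 3 (0.08 log units; within the scatter) and the step of a 1.6-fold higher number from compound 1 to compound 3 (0.22 log units; within the scatter) both stay inside the usual spread. The earlier pair showed only that one halogen could replace another without a readable shift, whereas the change from 4-bromophenyl to 4-nitrophenyl swaps a single bromine atom for a group of three heavy atoms with two hydrogen-bond acceptors, and it too leaves no readable shift, so no order can be read among the three compounds at this position. Nothing at hand offers an explanation for this flat result.

The compounds shown leave open whether a different kind of group on this aromatic carbon, such as an amine, a carboxylic acid or a longer alkyl chain, or a plain hydrogen, would move the number beyond the scatter. They also leave open whether changes elsewhere on the shared core matter more than changes at this position.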